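Chain variation on the aromatic nitrogen: nitrite read-out

A few compounds are considered here, and "the series" means these few. Any claim that something is new, unique, unknown or untested is made for them only; others in the source may bear on it.

Values in a functional assay on RAW264.7 cells (Mus musculus) for inhibition, read by Griess assay, with stated times of 2 h and 24 h; on this read-out lower numbers stand for stronger inhibition and higher numbers for weaker inhibition:

compound 1 `CCn1cc(COc2cc(O)c3c(c2)O[C@H](c2ccc(OC)c(O)c2)CC3=O)nn1`: 15000 nM
compound 2 `C=CCn1cc(COc2cc(O)c3c(c2)O[C@H](c2ccc(OC)c(O)c2)CC3=O)nn1`: 13800 nM
compound 3 `COc1ccc([C@@H]2CC(=O)c3c(O)cc(OCc4cn(Cc5ccccc5C(F)(F)F)nn4)cc3O2)cc1O`: 12500 nM

Compound 3 gives the lowest of the three numbers, but its separation from the others is small: a 1.1-fold lower number from compound 2 to compound 3 (0.04 log units; within the scatter) and a 1.2-fold lower number from compound 1 to compound 3 (0.08 log units; within the scatter). The three compounds are therefore indistinguishable in this assay, and none can be called the most active.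

Compound 4 `CCCCn1cc(COc2cc(O)c3c(c2)O[C@H](c2ccc(OC)c(O)c2)CC3=O)nn1` is not yet measured. Relative to compound 3 it carries the change (propyl in place of 2-(trifluoromethyl)phenyl on a saturated chain carbon bound to an aromatic nitrogen).

Within the data shown here, three measured steps bear on this position, all at the saturated chain carbon bound to the aromatic nitrogen: a 1.1-fold lower number from compound 1 to compound 2 (0.04 log units; within the scatter), a 1.2-fold lower number from compound 1 to compound 3 (0.08 log units; within the scatter) and a 1.1-fold lower number from compound 2 to compound 3 (0.04 log units; within the scatter). Each sits within the scatter, so methyl, vinyl and 2-(trifluoromethyl)phenyl at this place give the same number within measurement noise. Propyl is expected to behave likewise, and the step from compound 3 is estimated as a 1.1-fold higher number from compound 3 to compound 4 (0.05 log units; within the scatter), no change beyond the scatter. Compound 4 is therefore expected to give about 14000 nM in this assay, with a range from 7000 nM to 28000 nM.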

Compound 4, half-maximal inhibitory concentration: 13900 nM
Estimate against measurement, compound 4: 1.0-fold (0.00 log units) above, and the stated range covers the measured number.
By their numbers in this assay, from the lowest: compounds 3, 2, 4 and 1 (each within the scatter of the next).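

In this assay, butyl in place of 2-(trifluoromethyl)benzyl gives a 1.1-fold higher number from compound 3 to compound 4 (0.05 log units; within the scatter) as its step, and the other two new steps are a 1.0-fold higher number from compound 2 to compound 4 (0.00 log units; within the scatter) and a 1.1-fold lower number from compound 1 to compound 4 (0.03 log units; within the scatter) with no separation at this place. Earlier compounds left open whether the number held once the benzyl ring was gone and the saturated chain reached butyl; compound 4 shows that it does, with 2-(trifluoromethyl)phenyl (10 heavy atoms, one aromatic ring) and propyl (3 heavy atoms, no ring) exchanged on a saturated chain carbon bound to an aromatic nitrogen, and all four compounds remain indistinguishable. No supporting evidence is available to explain this flat read-out.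

Still open, as far as these compounds go, is whether an amine, a carboxylic acid or a chain longer than butyl at this place would give a step beyond the scatter. Also open is whether any such group would separate from the four compounds shown.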